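A nitro group added to the biphenyl compound

The compounds below may be only part of what the source reports. "The series", "measured", "known", "first", "only" and "open" are said of these compounds alone.

Compound 1, `CC(c1ccc(-c2ccccc2)c(F)c1)c1nnc2n1N=C(c1ccccc1)CS2`, gives 7400 nM in a functional assay on MCF7 cells (Homo sapiens) for inhibition, read by sulforhodamine B assay, with a stated time of 72 h; on this read-out lower numbers stand for stronger inhibition and higher numbers for weaker inhibition.
Compound 2, `COc1ccc2cc(C(C)c3nnc4n3N=C(c3ccc(F)cc3)CS4)ccc2c1`, gives 15800 nM in this assay.
Compound 3, `CC(C)Cc1ccc(C(C)c2nnc3n2N=C(c2ccc([N+](=O)[O-])cc2)CS3)cc1`, is reported only as "not active" (no number reported) in this assay, with no single number.

Compound 1 holds the lowest of the two numbers; compound 2 stands a step away that lies beyond the scatter, and compound 3 gave no number at all. Compound 4, `CC(c1ccc(-c2ccccc2)c(F)c1)c1nnc2n1N=C(c1ccc([N+](=O)[O-])cc1)CS2`, differs from compound 1 in one place: nitro in place of hydrogen on an aromatic carbon. Within the data shown here, no pair of measured compounds isolates this change, so the size of the step must be estimated. Among the measured compounds shown here, compound 3, the only measured compound carrying a nitro group, gave no number, which weighs toward weaker inhibition. Compound 4 is therefore expected to give 16000 nM, in the range 5000 nM to 60000 nM. The step from compound 1 is estimated as a 2.2-fold higher number from compound 1 to compound 4 (0.33 log units; beyond the scatter) toward weaker inhibition, likely just beyond the scatter.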

Compound 4, half-maximal inhibitory concentration: 7800 nM
The estimate for compound 4 lay 2.1-fold (0.31 log units) above the measured number; the range from low to high includes it.
By their numbers in this assay, from the lowest: compounds 1 and 4 (each within the scatter of the next); then compound 2.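

In this assay, among these compounds, the change from phenyl to 4-nitrophenyl reads as a 1.1-fold higher number from compound 1 to compound 4 (0.02 log units; within the scatter) and so gives a first measured number for a nitro-bearing compound. On this read-out, nitro and hydrogen cannot be told apart at this position, on an aromatic carbon para to a large group. Nothing measured here explains this result. On these data alone, whether an amine or a carboxylic acid at the same place would also stay within the scatter remains open, as does whether the nitro change reads alike on a compound without the biphenyl group.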